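Replacing the hydantoin of compound 1 with a thiazolidinedione linked by a double bond

The source may hold more compounds than are shown below. What is called first, only, known or untested is meant among the compounds shown, and "the series" means these compounds.

Measured so far:
compound 1 `CC(C)C(c1ccc(-c2ccc3cccc(F)c3c2)[nH]c1=O)C1C(=O)NC(=O)N1C`, 46 nM
compound 2 `CC(C)[C@@H](c1ccc(-c2ccc3cccc(F)c3c2)[nH]c1=O)[C@@H]1OC(=O)NC1=O`, 85 nM
compound 3 `CC(C)/C(=C1/SC(=O)NC1=O)c1ccc(-c2ccc3cccc(F)c3c2)[nH]c1=O`, 22 nM

In an assay on membranes from Chem-1 cells for displacement of a labelled ligand from prostaglandin E2 receptor EP3 subtype (Homo sapiens), read by scintillation counting, with a stated time of 2 h (on this read-out higher numbers stand for weaker inhibition and lower numbers for stronger inhibition), compound 1 gives 46 nM, the second highest of the three numbers. Compound 2 lies within the scatter of it, so no order between them can be read; compound 3 sits beyond the scatter at a lower number.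

Compound 4 `CC(C)C(/C=C1\SC(=O)NC1=O)c1ccc(-c2ccc3cccc(F)c3c2)[nH]c1=O` has not been measured. It differs from compound 1 in one place: a group of 8 heavy atoms (4 carbon, 1 nitrogen, 2 oxygen, 1 sulfur; one five-membered non-aromatic ring with 2 hetero atoms) in place of a group of 8 heavy atoms (4 carbon, 2 nitrogen, 2 oxygen; one five-membered non-aromatic ring with 2 hetero atoms), on a saturated chain carbon bound to an aromatic carbon and a saturated chain carbon. Going by the values given here, compound 3 carries the same sulfur-containing ring and gives 22 nM, but no measured pair shows this exact exchange. The step from compound 1 to compound 4 is expected to be a 1.3-fold lower number from compound 1 to compound 4 (0.12 log units; within the scatter), small and toward a lower number. Compound 4 is therefore estimated at 35 nM, with a range from 12 nM to 110 nM.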

Compound 4, inhibition constant: 13 nM
Estimate against measurement, compound 4: 2.7-fold (0.43 log units) above; measured number inside the range.
By their numbers in this assay, from the lowest: compounds 4 and 3 (each within the scatter of the next); then compounds 1 and 2 (each within the scatter of the next).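

In this assay, going by these compounds alone, exchanging the 3-methyl-2,5-dioxoimidazolidin-4-yl group for the sulfur-containing ring gives a 3.5-fold lower number from compound 1 to compound 4 (0.55 log units; beyond the scatter), the first step read across a single place. It shows that the number at this saturated chain carbon responds to the ring attached there, even though the group that enters has the same heavy-atom count as the one that leaves. Nothing measured here explains the step. The compounds shown do not separate the part played by the sulfur from that of the added double bond. They also leave open how a carboxylic acid would fare in this place.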